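Chloro for nitro on the phenyl arm of compound 1

The compounds below may be only part of what the source reports. "The series", "measured", "known", "first", "only" and "open" are said of these compounds alone.

In an ADME assay on NIH3T3 cells (Mus musculus) for cytotoxicity, read by XTT assay, with a stated time of 24 h (on this read-out higher numbers stand for weaker inhibition and lower numbers for stronger inhibition), the measured compounds stand as follows:
compound 1, `Cc1ccc(C2=NN(c3nc(-c4ccc([N+](=O)[O-])cc4)cs3)C(c3ccc(F)cc3)C2)s1`: 15.6 ug/mL
compound 2, `N#Cc1ccc(-c2csc(N3N=C(c4ccc(Cl)s4)CC3c3ccc(F)cc3)n2)cc1`: compound 2 gives > 500 ug/mL
compound 3, `O=[N+]([O-])c1ccc(-c2csc(N3N=C(c4ccc(Cl)s4)CC3c3ccc(F)cc3)n2)cc1`: compound 3 gives > 500 ug/mL

Among the measured compounds shown here, compound 1 holds the only actual number. For compound 2 the reading is a limit of the assay, not a number. For compound 3 the reading is likewise a limit of the assay. Compound 4, `Cc1ccc(C2=NN(c3nc(-c4ccc(Cl)cc4)cs3)C(c3ccc(F)cc3)C2)s1`, has not yet been measured; it differs from compound 1 by chloro in place of nitro on an aromatic carbon.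

For the measured compounds named here, no measured step covers this exact exchange. The step from compound 2 to compound 3 sits at the same ring but reads as a step that the two limits leave unreadable from compound 2 to compound 3. The step of an at least 32-fold higher number from compound 1 to compound 3 (1.50 log units; beyond the scatter) shows that a single exchange elsewhere on the scaffold can move the reading from a number to the limit, and the limit of > 500 ug/mL in this assay, at which 2 of the 3 values shown sit, is where most of the shown readings end.

Given that, compound 4 is expected to lie above compound 1, by an estimated 3.8-fold higher number from compound 1 to compound 4 (0.59 log units; beyond the scatter), with a fair chance of reaching only a limit. The estimate for compound 4 in this assay is 60 ug/mL, with a range from 10 ug/mL to 500 ug/mL.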

Compound 4, half-maximal inhibitory concentration: > 500 ug/mL
Compound 4 was reported as a limit; the forecaster's own chance of this, stated with the estimate: 35%; middle value at least 8.3-fold (0.92 log units) away from the limit.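

In this assay, among the compounds shown here, the change from 4-nitrophenyl to 4-chlorophenyl gives an at least 32-fold higher number from compound 1 to compound 4 (1.50 log units; beyond the scatter), the first readable step at this position, whereas the earlier step from nitrile to nitro on this ring cannot be read. The reading of compound 4 is a limit of the assay, not a number. Compound 1 thus leaves the measurable range through either of two single exchanges, chloro for nitro here and chloro for methyl in compound 3, so neither the nitro group kept in compound 3 nor the methyl group kept in compound 4 is enough on its own to hold a number, and compound 1 alone stays off the limit: the limit of > 500 ug/mL in this assay, at which 3 of the 4 values shown sit.

As far as these compounds go, whether an amine or a carboxylic acid in place of the nitro group of compound 1 would keep a number or reach the limit stays open. From the compounds shown here alone, the full size of the step also stays open, as does whether chloro differs in any way from nitrile or nitro once the reading sits at the limit.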